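A few compounds are considered here, and "the series" means these few. Any claim that something is new, unique, unknown or untested is made for them only; others in the source may bear on it.

Working notes on the series. Among the measured compounds shown here, compound 2 `CCOC(=O)C1=C(N/N=C(/C(=O)Br)c2ccc(Cl)cc2)Nc2[nH]nc(C)c2C1c1ccc(N(C)C)cc1` is the higher of the two numbers so far in a functional assay on MCF7 cells (Homo sapiens) for inhibition, read by MTT assay, with a stated time of 48 h; on this read-out lower numbers stand for stronger inhibition and higher numbers for weaker inhibition; compound 2 gives 46300 nM. Its nearest neighbour is compound 1 `CCOC(=O)C1=C(N/C=N/c2ccccn2)Nc2[nH]nc(C)c2C1c1ccc(N(C)C)cc1`, which in this assay gives 37300 nM, and the change between them, a 1.2-fold higher number from compound 1 to compound 2 (0.09 log units; within the scatter), leaves the two within the scatter.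

Compound 3 `CCOC(=O)C1=C(N/N=C(/Cl)c2ccc([N+](=O)[O-])cc2)Nc2[nH]nc(C)c2C1c1ccc(N(C)C)cc1` is the next entry. It differs from compound 2 in one place: a group of 12 heavy atoms (7 carbon, 2 nitrogen, 2 oxygen, 1 chlorine; one six-membered aromatic ring of carbon only) in place of a group of 12 heavy atoms (8 carbon, 1 nitrogen, 1 oxygen, 1 chlorine, 1 bromine; one six-membered aromatic ring of carbon only), on an amine nitrogen.

For the measured compounds named here, the only measured step that bears on this is the one from compound 1 to compound 2, which also replaced the group on the same amine nitrogen and gave a 1.2-fold higher number from compound 1 to compound 2 (0.09 log units; within the scatter). On that basis no step beyond the scatter is expected for compound 3 in this assay, so the expected step is a 1.0-fold lower number from compound 2 to compound 3 (0.01 log units; within the scatter). The estimate for compound 3 in this assay is 45000 nM, with a range from 20000 nM to 100000 nM.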

Compound 3, half-maximal inhibitory concentration: 52700 nM
Estimate against measurement, compound 3: 1.2-fold (0.07 log units) below; low and high end bracket the measured number.
By their numbers in this assay, from the lowest: compounds 1, 2 and 3 (each within the scatter of the next).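

On the amine nitrogen whose other neighbour is the double-bonded ring carbon, a group of 12 heavy atoms with 3 hydrogen-bond acceptors in place of one with 2, and with no bromine, gives a 1.1-fold higher number from compound 2 to compound 3 (0.06 log units; within the scatter) in this assay. Set against the group of 8 heavy atoms with a hetero atom in its ring, the same group gives a 1.4-fold higher number from compound 1 to compound 3 (0.15 log units; within the scatter), so the three groups shown at this place all lie within the scatter of one another. No accompanying measurement offers an account of these numbers.

On these data alone, all three groups carry a six-membered aromatic ring, and what a short alkyl chain, an amine or a carboxylic acid on this nitrogen would give remains open. Also open, as far as these compounds go, is how the series responds to changes elsewhere, such as at the ethyl ester or the dimethylamino group.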